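Adding Propoxy to Compound 2

The compounds below may be only part of what the source reports. "The series", "measured", "known", "first", "only" and "open" are said of these compounds alone.

Compound 1 `CSc1ccc(-c2nc3cc[nH]cc-3n2)cc1`: 4 mg/kg
Compound 2 `COc1ccc(-c2nc3cc[nH]cc-3n2)cc1`: 1.7 mg/kg
Compound 3 `COc1ccc(-c2nc3cc[nH]cc-3n2)cc1OC`: 0.4 mg/kg

In a functional assay on the whole organism with Canis familiaris (Canis lupus familiaris) as the target (a higher number here means that more compound is needed for the effect, a lower number that less compound is needed), compound 2 gives 1.7 mg/kg, the second highest of the three numbers. Compound 4 `CCCOc1cc(OC)ccc1-c1nc2cc[nH]cc-2n1` differs from it by a single change, propoxy in place of hydrogen on an aromatic carbon. The closest measured precedent is methoxy in place of hydrogen on an aromatic carbon, a modest step: a 4.3-fold lower number from compound 2 to compound 3 (0.63 log units; beyond the scatter). The exchange of methylsulfanyl for methoxy, also modest, bears on it less directly: a 2.4-fold lower number from compound 1 to compound 2 (0.37 log units; beyond the scatter). For the measured compounds named here, no propoxy compound has been measured, so a lower number of similar or somewhat smaller size is expected, with wide uncertainty. The estimated step is a 2.8-fold lower number from compound 2 to compound 4 (0.45 log units; beyond the scatter). For compound 4 the expected value is 0.6 mg/kg, within an estimated range of 0.15 mg/kg to 2.2 mg/kg.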

Compound 4, dose for half-maximal effect: 1.3 mg/kg
Estimate against measurement, compound 4: 2.2-fold (0.34 log units) below; the range from low to high includes it.
By their numbers in this assay, from the lowest: compound 3; then compounds 4 and 2 (each within the scatter of the next); then compound 1.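

Propoxy on the aromatic carbon ortho to a group of 9 heavy atoms and meta to a methoxy group gives a 1.3-fold lower number from compound 2 to compound 4 (0.12 log units; within the scatter) in this assay. Adding to the ring of compound 2 therefore does not always bring the fall seen in a 4.3-fold lower number from compound 2 to compound 3 (0.63 log units; beyond the scatter), where methoxy occupies a different ring carbon. Nothing available here accounts for this contrast.

The compounds shown leave open whether the group or the place sets the outcome, since neither changes alone. Methoxy, ethoxy or an amine on this same carbon would separate the two.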